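Adding a Phenylethynyl Group to the Aromatic Core of Compound 1

The compounds below may be only part of what the source reports. "The series", "measured", "known", "first", "only" and "open" are said of these compounds alone.

Compound 1 `O=c1nc2c(cn1Cc1ccccc1)ncn2Cc1ccccc1` carries two benzyl groups on a fused aromatic core and a hydrogen on the ring carbon in question. In a functional assay on K562 cells (Homo sapiens), read by thymidine incorporation, with a stated time of 5 h (a higher number here means a weaker inhibitor, a lower number a stronger inhibitor), compound 1 gives only > 10 ug/mL, which is a limit of the assay and not a number. Two compounds with a saturated ring carbon in the shared core have been measured. Compound 2 `O=C1Nc2c(ncn2Cc2ccccc2)C(C#Cc2ccccc2)N1Cc1ccccc1` bears a 2-phenylethynyl group on that saturated carbon and gives 1.4 ug/mL in this assay. Compound 3 `O=C1Nc2c(ncn2Cc2ccccc2)C(c2ccccc2)N1Cc1ccccc1` bears a phenyl group there and gives 5.1 ug/mL. The change a 3.6-fold higher number from compound 2 to compound 3 (0.56 log units; beyond the scatter) shows the phenyl analogue as the weaker of the two. Compound 4 `O=c1nc2c(ncn2Cc2ccccc2)c(C#Cc2ccccc2)n1Cc1ccccc1` is compound 1 with 2-phenylethynyl in place of hydrogen on an aromatic carbon. Within the data shown here, no measured pair shares exactly this change; the step from compound 2 to compound 3 bears on it only in that the same 2-phenylethynyl group stands in the stronger of those two compounds, on a saturated carbon. Because compound 1 sits at the limit of > 10 ug/mL in this assay, at which 1 of the 3 values shown sits, the step from compound 1 can only run towards a lower number or stay unresolved. Compound 4 is therefore expected to give 3 ug/mL, with a range from 0.8 ug/mL to 15 ug/mL. The expected step is an at least 3.3-fold lower number from compound 1 to compound 4 (0.52 log units; beyond the scatter).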

Compound 4, half-maximal inhibitory concentration: 1 ug/mL
For compound 4 the middle estimate is 3.0-fold (0.48 log units) above the measured one, and the stated range covers the measured number.
By their numbers in this assay, from the lowest: compounds 4 and 2 (each within the scatter of the next); then compound 3. At a limit, above all of these: compound 1.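

In this assay compound 1 gives > 10 ug/mL, which is a limit of the assay and not a number. On the aromatic carbon next to the ring nitrogen and ortho to a benzyl group, 2-phenylethynyl in place of hydrogen gives an at least 10-fold lower number from compound 1 to compound 4 (1.00 log units; beyond the scatter), the first step shown at an aromatic carbon, as the earlier step concerned only a saturated ring carbon. The true size of this step stays unresolved and could be larger than printed, because compound 1 stands at a limit: the limit of > 10 ug/mL in this assay, at which 1 of the 4 values shown sits.

The compounds shown leave open whether this aromatic carbon needs the triple bond at all, or whether a phenyl group set directly on it, or a longer chain ending in an amine or a carboxylic acid, would give a similar number. They also leave open how 2-phenylethynyl on the saturated ring carbon compares with a plain hydrogen there, and how much of the step from hydrogen belongs to the triple bond and how much to the phenyl ring at its end.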